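The source may report more compounds than this note shows. Statements on the series, on what has been measured and on what is new or still open speak of the compounds shown alone.

The measured compounds in an ADME assay on MT4 cells (Homo sapiens) for cytotoxicity, read by MTT assay, with a stated time of 4 days; a higher number here means that more compound is tolerated, a lower number that less compound is tolerated:
compound 1 `N#Cc1ccc(Nc2nc(Oc3ccccc3Cl)c3ccccc3n2)cc1`, 38000 nM
compound 2 `COc1ccccc1Oc1nc(Nc2ccc(C#N)cc2)nc2ccccc12`, 150000 nM
compound 3 `N#Cc1ccc(Nc2nc(Oc3ccccc3)c3ccccc3n2)cc1`, 370000 nM

Compound 1 has the lowest number of the three in this assay: the step of a 3.9-fold higher number from compound 1 to compound 2 (0.60 log units; beyond the scatter) and the step of a 9.7-fold higher number from compound 1 to compound 3 (0.99 log units; beyond the scatter) both run upward from it, each beyond the scatter. Compound 4 `N#Cc1ccc(Nc2nc(Oc3c(Cl)cc(Cl)cc3Cl)c3ccccc3n2)cc1` differs from compound 1 by 2,4,6-trichlorophenyl in place of 2-chlorophenyl on an oxygen on an aromatic ring. Within the data shown here, the steps that bear on this change are the two that take the chloro away from compound 1, and both raised the number; adding two further chloro atoms is therefore expected to move the number the other way, by a modest step downward a 2.9-fold lower number from compound 1 to compound 4 (0.47 log units; beyond the scatter). Compound 4 is estimated at 13000 nM, with a range from 4000 nM to 40000 nM.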

Compound 4, half-maximal cytotoxic concentration: 56000 nM
For compound 4 the middle estimate is 4.3-fold (0.63 log units) below the measured one; the measured number lies above the stated range.
By their numbers in this assay, from the lowest: compounds 1 and 4 (each within the scatter of the next); then compound 2; then compound 3.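

In this assay, 2,4,6-trichlorophenyl and 2-chlorophenyl on this oxygen cannot be told apart, at a 1.5-fold higher number from compound 1 to compound 4 (0.17 log units; within the scatter), so the two further chlorine atoms bring no separable change. The trichlorinated ring remains clearly apart from the other two rings, at a 6.6-fold lower number from compound 3 to compound 4 (0.82 log units; beyond the scatter) and at a 2.7-fold lower number from compound 2 to compound 4 (0.43 log units; beyond the scatter), so among these four compounds, one chlorine and three chlorines both give the lowest numbers. Nothing shown here explains this result. The compounds shown leave open whether a ring carrying bromo, an amine or a carboxylic acid on this oxygen would also fall with the chlorinated compounds.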